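Longer bromo chain, with every value at the limit

The source may report more compounds than this note shows. Statements on the series, on what has been measured and on what is new or still open speak of the compounds shown alone.

Measured in an ADME assay on L929 cells (Mus musculus) for cytotoxicity, read by resazurin assay, with a stated time of 48 h; on this read-out lower numbers stand for higher toxicity in this test and higher numbers for lower toxicity in this test:
- compound 1 `NC(=O)CCCn1c2ccc([N+](=O)[O-])cc2c(=O)n1Cc1ccccc1`: > 256000 nM, a limit
- compound 2 `CN(C)C(=O)CCCn1c2ccc([N+](=O)[O-])cc2c(=O)n1Cc1ccccc1`: > 256000 nM, a limit
- compound 3 `O=[N+]([O-])c1ccc2nn(Cc3ccccc3)c(OCCBr)c2c1`: > 256000 nM, a limit

Compound 3 has no exact number, only the limit > 256000 nM. It stands level with the other two compounds, and the evidence is the same throughout: the limit of > 256000 nM in this assay, at which 3 of the 3 values shown sit.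

Compound 4 `O=[N+]([O-])c1ccc2nn(Cc3ccccc3)c(OCCCBr)c2c1` carries 3-bromopropoxy where compound 3 carries 2-bromoethoxy: bromomethyl in place of bromo on a saturated chain carbon, two bonds along the chain from an oxygen on an aromatic ring. For the measured compounds named here, the one measured step is a step that the two limits leave unreadable from compound 1 to compound 2. It concerns dimethylamino in place of amino on a carbonyl carbon, not the bromo chain, so it gives no size to carry over.

No step beyond the usual scatter is therefore expected in this assay, and no direction is expected either. The expected step is a number no higher from compound 3 to compound 4 (the limit leaves the size open). Compound 4 is estimated at 256000 nM, with an expected range of 110000 nM to 256000 nM, and it will most likely be reported only as a limit.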

Compound 4, concentration lethal to 50% of the cells: 59000 nM
Compound 4: the middle estimate sits 4.3-fold (0.64 log units) above what was measured; measured number outside the range, below it.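

In this assay, the chain carrying the bromine proves to be a place where the read-out can move: 3-bromopropoxy in place of 2-bromoethoxy gives an at least 4.3-fold lower number from compound 3 to compound 4 (0.63 log units; beyond the scatter), and a lower number here stands for higher toxicity in this test. The true size of this step stays open, as compound 3 has only a limit, and the one other step shown, dimethylamino in place of amino on a carbonyl carbon, cannot be read. Compound 4 is the only compound shown that carries an exact number rather than a limit: the limit of > 256000 nM in this assay, at which 3 of the 4 values shown sit.

The compounds shown leave open whether a still longer chain, such as 4-bromobutoxy, would lower the number further. They also leave open whether the bromine is needed, which a plain propoxy or a 3-chloropropoxy chain in the same place would address.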